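Adding chlorine to a weak aryl ether

The compounds below may be only part of what the source reports. "The series", "measured", "known", "first", "only" and "open" are said of these compounds alone.

Compound 1 `NC1=NC2(CCSCC2)N(OCCCOc2ccc(Cl)c(Cl)c2)C(N)=N1`: 140 nM
Compound 2 `CC(C)(C)c1ccc(OCCCON2C(N)=NC(N)=NC23CCSCC3)cc1`: 280 nM
Compound 3 `NC1=NC2(CCOCC2)N(OCCCOc2ccccc2Cl)C(N)=N1`: 660 nM

All three values come from a functional assay on HL-60 cells (Homo sapiens) for antiproliferative activity, read by MTT assay, with a stated time of 72 h; a higher number here means a weaker inhibitor, a lower number a stronger inhibitor. Compound 3 gives 660 nM, the highest of the three numbers, which makes it the weakest inhibitor of the set. Its gaps to the other two both lie beyond the scatter.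

Compound 4 `NC1=NC2(CCOCC2)N(OCCCOc2cc(Cl)c(Cl)cc2Cl)C(N)=N1` keeps the rest of compound 3 and changes one group: 2,4,5-trichlorophenyl in place of 2-chlorophenyl on an oxygen on a saturated carbon.

Going by the values given here, no measured pair isolates this change, so any expectation is loose. Compound 1 also has chlorine on its aromatic ring and gives 140 nM, a lower number than compound 3, but its core is different. Compound 2 goes against any simple link with chlorine, since it has none and still gives 280 nM.

A moderate move towards stronger inhibition in this assay is expected, and the estimated change is a 2.9-fold lower number from compound 3 to compound 4 (0.46 log units; beyond the scatter). With so little direct evidence, a result within the scatter of compound 3 would not be surprising. For compound 4 the estimated value is 230 nM, with an expected range from 70 nM to 700 nM.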

Compound 4, half-maximal inhibitory concentration: 2360 nM
Beside the measured number, compound 4's estimate is 10-fold (1.01 log units) below it; measured number above the stated range.
By their numbers in this assay, from the lowest: compounds 1 and 2 (each within the scatter of the next); then compound 3; then compound 4.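

In this assay, placing 2,4,5-trichlorophenyl in place of 2-chlorophenyl on an oxygen on a saturated carbon gives a 3.6-fold higher number from compound 3 to compound 4 (0.55 log units; beyond the scatter) and so marks a loss of inhibition that lies beyond the scatter. Going by these compounds alone, this is the only pair here that differs in one place, so it is the first direct reading of this change on this core: more chlorine on this aromatic ring goes with weaker inhibition for this pair alone. Compound 1 and compound 2 differ from compound 3 in more than one place and could not show this, and nothing available explains why the number rises.

The compounds shown leave open which of the added chlorine atoms accounts for the step, since only the complete 2,4,5-trichlorophenyl group stands against 2-chlorophenyl. They also leave open how the same core would respond to a different group on this aromatic ring, such as a methoxy group or an amine in place of the chlorine.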